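A few compounds are considered here, and "the series" means these few. Any claim that something is new, unique, unknown or untested is made for them only; others in the source may bear on it.

Compound 1 `CC1C(=O)N(O)C(=O)c2ccccc21`: 250000 nM
Compound 2 `CCC1C(=O)N(O)C(=O)c2ccccc21`: 250000 nM

In an ADME assay on MT4 cells (Homo sapiens) for cytotoxicity, read by MTT assay (on this read-out lower numbers stand for higher toxicity in this test and higher numbers for lower toxicity in this test), level with compound 1, compound 2 gives 250000 nM. Compound 3 `CCCCCC1C(=O)N(O)C(=O)c2ccccc21` keeps the shared core and differs from compound 2 in one place: propyl in place of hydrogen on a saturated chain carbon, two bonds along the chain from a saturated ring carbon. In other words, ethyl becomes pentyl.

Going by the values given here, only one measured step bears on this change: no change at the digits printed from compound 1 to compound 2 (within the scatter), which was methyl in place of hydrogen on a saturated chain carbon bound to a saturated ring carbon. Among the compounds with values here, that step is a smaller addition than propyl, and no compound with a chain as long as pentyl has been measured, so the evidence is thin. A modest move toward lower numbers in this assay is expected, though it may stay within the scatter. The expected change is a 1.6-fold lower number from compound 2 to compound 3 (0.19 log units; within the scatter). For compound 3 the estimated value is 160000 nM, with an expected range of 60000 nM to 280000 nM.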

Compound 3, half-maximal cytotoxic concentration: 98300 nM
Beside the measured number, compound 3's estimate is 1.6-fold (0.21 log units) above it, and the stated range covers the measured number.
By their numbers in this assay, from the lowest: compound 3; then compounds 1 and 2 (each within the scatter of the next).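

In this assay, going by these compounds alone, the change from ethyl to pentyl gives the first step at this position that lies beyond the scatter: a 2.5-fold lower number from compound 2 to compound 3 (0.41 log units; beyond the scatter). Set against the smaller addition of methyl, which gave no change at the digits printed from compound 1 to compound 2 (within the scatter), the longer addition shows that the number in this test does respond to chain length here, and the step with butyl in place of hydrogen is the same size, a 2.5-fold lower number from compound 1 to compound 3 (0.41 log units; beyond the scatter). Nothing available accounts for this shift.

Three compounds cannot show whether the numbers keep falling with a longer chain, such as octyl, or level off beyond pentyl. As far as these compounds go, it also remains open how a branched chain, or an amine or a carboxylic acid carried on the chain, would read in this assay.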